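Two measured analogues and a third still to be tested

The compounds below may be only part of what the source reports. "The series", "measured", "known", "first", "only" and "open" are said of these compounds alone.

Measured in a functional assay on FM3A cells (Mus musculus) for cytotoxicity, read by cell counting, with a stated time of 2 days; on this read-out higher numbers stand for weaker inhibition and lower numbers for stronger inhibition:
Compound 1 `C=C(Br)C(=O)Nc1ccc(/C=C2\SC(=O)N(Cc3cccc(Cl)c3)C2=O)cc1` gives 6100 nM.
Compound 2 `C=C(Br)C(=O)Nc1cccc(/C=C2\SC(=O)N(Cc3ccccc3)C2=O)c1` gives 810 nM.

Of these two numbers compound 1 stands highest; compound 2 gives the lower number, and the gap between them is beyond the scatter.

Compound 3 `C=C(Br)C(=O)Nc1ccc(/C=C2\SC(=O)N(Cc3ccc(C(F)(F)F)cc3)C2=O)cc1` differs from compound 1 by 4-(trifluoromethyl)phenyl in place of 3-chlorophenyl on a saturated chain carbon bound to an amide-type nitrogen in a ring. Among the measured compounds shown here, no measured pair shows this change, so its effect is unknown. Compound 3 is expected to stay near compound 1, with an expected step of a 1.0-fold lower number from compound 1 to compound 3 (0.01 log units; within the scatter) not beyond the scatter. The estimate for compound 3 is 6000 nM, expected to fall between 2000 nM and 18000 nM.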

Compound 3, half-maximal inhibitory concentration: 23000 nM
For compound 3 the middle estimate is 3.8-fold (0.58 log units) below the measured one, and the stated range ends below it.
By their numbers in this assay, from the lowest: compound 2; then compound 1; then compound 3.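

In this assay, 4-(trifluoromethyl)phenyl in place of 3-chlorophenyl on a saturated chain carbon bound to an amide-type nitrogen in a ring gives a 3.8-fold higher number from compound 1 to compound 3 (0.58 log units; beyond the scatter) and so weaker inhibition. This position is therefore not indifferent to the aryl group it carries, at least for this pair. Nothing given here accounts for the step.

The change alters both the substituent and where it stands on the phenyl ring, so the two contributions cannot be separated. On these data alone, how 4-chlorophenyl, or a phenyl ring carrying an amine or a carboxylic acid, would behave here remains open.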